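A few compounds are considered here, and "the series" means these few. Any claim that something is new, unique, unknown or untested is made for them only; others in the source may bear on it.

Measured compounds in a functional assay on PC-3 cells (Homo sapiens) for cytotoxicity, read by MTT assay, with a stated time of 72 h; a lower number here means a stronger inhibitor, a higher number a weaker inhibitor:

compound 1, `COc1cc(/C=C/C(=O)/C=C/C2=C(C)CCCC2(C)C)ccc1O`, 21300 nM
compound 2, `COc1ccc(/C=C/C(=O)/C=C/C2=C(C)CCCC2(C)C)cc1OC`, 42000 nM
compound 3, `CC1=C(/C=C/C(=O)/C=C/c2cc(C(F)(F)F)cc(C(F)(F)F)c2)C(C)(C)CCC1`, 7200 nM

Among these three numbers compound 1 stands second highest. Its nearest neighbour is compound 2, reached by a 2.0-fold higher number from compound 1 to compound 2 (0.29 log units; within the scatter), a step that stays within the scatter. Going by the values given here, compound 3 lies furthest away, with a lower number than compound 1 that falls beyond the scatter; no single-point step joins these two, so their two values can only be set side by side.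

Compound 4, `CC1=C(/C=C/C(=O)/C=C/c2ccc(O)c([N+](=O)[O-])c2)C(C)(C)CCC1`, is not yet measured. It differs from compound 1 in one place: nitro in place of methoxy on an aromatic carbon. Among the compounds with values here, none of the measured steps covers this exchange. Within the data shown here, the only measured step, from compound 1 to compound 2, swaps a methyl for a hydrogen on an oxygen and changes nothing beyond the scatter, so it gives no guidance on a nitro in place of methoxy. Compound 3, with its pair of trifluoromethyl groups, shows a lower number than compound 1, but its ring carries neither hydroxy nor methoxy, so it is no template either.

Among the measured compounds shown here, with no bearing step available, the expectation for compound 4 in this assay is a modest change at most, about a 1.4-fold lower number from compound 1 to compound 4 (0.15 log units; within the scatter), and the estimated value is 15000 nM with a range from 5000 nM to 45000 nM.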

Compound 4, half-maximal inhibitory concentration: > 50000 nM
Compound 4 was reported as a limit (the forecaster's own chance of this, stated with the estimate: 5%); middle value at least 3.3-fold (0.52 log units) from the limit.
By their numbers in this assay, from the lowest: compound 3; then compounds 1 and 2 (each within the scatter of the next). At a limit, above all of these: compound 4.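

In this assay, placing nitro instead of methoxy on this aromatic carbon, ortho to a hydroxy group, gives an at least 2.3-fold higher number from compound 1 to compound 4 (0.37 log units; beyond the scatter), so a single exchange at this position moves the result beyond the scatter. The earlier step, a 2.0-fold higher number from compound 1 to compound 2 (0.29 log units; within the scatter), put a methyl on the oxygen of the hydroxy group and stayed within the scatter, which makes this aromatic carbon the one place shown where a single exchange has a clear effect. For compound 4 the reading of > 50000 nM is a limit and not a number, so the new step gives a direction and a minimum size only: the limit of > 50000 nM in this assay, at which 1 of the 4 values shown sits.

As far as these compounds go, what a plain hydrogen, an amine or a carboxylic acid on this aromatic carbon would do remains open, and with it the question of whether losing the methoxy or gaining the nitro matters more. Also open, from the compounds shown here alone, is how a longer chain on the oxygen of the methoxy group would read in this assay.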